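The source may report more compounds than this note shows. Statements on the series, on what has been measured and on what is new or still open speak of the compounds shown alone.

Two compounds of the series have numbers in a functional assay on T47D cells (Homo sapiens) for cytotoxicity, read by sulforhodamine B assay, with a stated time of 48 h; a higher number here means a weaker inhibitor of growth, a lower number a stronger inhibitor of growth. Compound 1 `ClCc1ccccc1Cn1cnc2c(Cl)nc(Cl)nc21` gives 1990 nM in this assay, the lowest of the two; compound 2 `Nc1nc(Cl)c2ncn(Cc3ccc(CCl)cc3)c2n1` gives 6920 nM in this assay, a gap beyond the scatter. Compound 3 `ClCc1ccccc1Cn1cnc2c(Cl)ncnc21` is unmeasured. Its difference from compound 1: hydrogen in place of chloro on an aromatic carbon, on an aromatic carbon between two ring nitrogen atoms of the shared core. Going by the values given here, no measured pair shows this change, so its size is unknown; a modest rise in the number, near or just past the scatter, is expected, as a 1.8-fold higher number from compound 1 to compound 3 (0.25 log units; within the scatter). For compound 3 a value of 3500 nM in this assay is estimated, with a range from 1200 nM to 10000 nM.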

Compound 3, concentration for 50% growth inhibition: 17800 nM
The estimate for compound 3 lay 5.1-fold (0.71 log units) below the measured number; measured number outside the range, above it.
By their numbers in this assay, from the lowest: compound 1; then compound 2; then compound 3.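

The chloro group on the aromatic carbon between two ring nitrogen atoms matters in this assay: with hydrogen in its place, the series gives its first single-place reading, an 8.9-fold higher number from compound 1 to compound 3 (0.95 log units; beyond the scatter). The other chloro group on the core, meta to this carbon, remains in compound 3 and does not keep the number near that of compound 1. Nothing measured on these compounds explains the step.

As far as these compounds go, whether chloro itself is needed here remains open, since fluoro, bromo, methyl or methoxy on this carbon would each give a further reading. From the compounds shown here alone, whether the step holds with the chloromethyl group elsewhere on the benzyl ring also remains open.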